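The source may hold more compounds than are shown below. What is called first, only, known or untested is meant among the compounds shown, and "the series" means these compounds.

Measured so far:
Compound 1 `Cc1cccn2c(/C=N/OCc3cn(Cc4ccc([N+](=O)[O-])cc4)nn3)c(-c3ccc(F)cc3)nc12`: 40 mg/kg
Compound 2 `COc1ccc(Cn2cc(CO/N=C/c3c(-c4ccc(F)cc4)nc4c(C)cccn34)nn2)cc1`: 40 mg/kg

In a functional assay on the whole organism (strain NMRI) with Mus musculus as the target, with a stated time of 4 h (on this read-out lower numbers stand for an effect already at smaller amounts and higher numbers for an effect only at larger amounts of compound), compound 2 gives 40 mg/kg, level with compound 1 at the digits printed, and the step of no change at the digits printed from compound 1 to compound 2 (within the scatter) shows no change within the usual scatter. Compound 3 `Cc1cccn2c(/C=N/OCc3cn(Cc4ccc(C#N)cc4)nn3)c(-c3ccc(F)cc3)nc12` differs from compound 2 by cyano in place of methoxy on an aromatic carbon. Going by the values given here, the only measured step that bears on this one is the exchange of the group on the same aromatic carbon from compound 1 to compound 2, which moved the dose not at all beyond the scatter. A step of about the same size, that is none beyond the scatter, is therefore expected here, as no change at the digits printed from compound 2 to compound 3 (within the scatter). Compound 3 is expected to give 40 mg/kg, within a range from 20 mg/kg to 80 mg/kg.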

Compound 3, minimum effective dose: 40 mg/kg
Compound 3: the middle estimate sits on the measured number at the digits printed; low and high end bracket the measured number.
By their numbers in this assay, from the lowest: compounds 1, 2 and 3 (each within the scatter of the next).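

In this assay, cyano in place of methoxy gives no change at the digits printed from compound 2 to compound 3 (within the scatter), and cyano in place of nitro gives no change at the digits printed from compound 1 to compound 3 (within the scatter), so this position on the benzyl ring now has three groups on record. Across nitro, methoxy and cyano, on an aromatic carbon para to a large group, the choice of group leaves the dose level in these three compounds. Nothing on hand explains this sameness.

Still open, as far as these compounds go, is whether an amine, a carboxylic acid or a longer chain at this position would shift the dose. The same question stands for a bare hydrogen there.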